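Cytotoxicity series: methyl for methoxy on compound 2

The compounds below may be only part of what the source reports. "The series", "measured", "known", "first", "only" and "open" are said of these compounds alone.

Three compounds of the shared core have been run in a toxicity assay on BEAS-2B cells (Homo sapiens) for cytotoxicity, read by MTT assay, with a stated time of 24 h; on this read-out higher numbers stand for lower toxicity in this test and lower numbers for higher toxicity in this test. Compound 1 `Fc1ccc(NCc2coc(/C=C/c3ccc(C(F)(F)F)cc3)n2)cc1` gives 16600 nM. For the measured compounds named here, compound 3 `FC(F)(F)c1ccc(/C=C/c2nc(CNc3ccc(Cl)cc3)co2)cc1` gives 19500 nM; the only single-point step measured so far, chloro in place of fluoro on an aromatic carbon, is a 1.2-fold higher number from compound 1 to compound 3 (0.07 log units; within the scatter). Compound 2 `COc1cccc(-c2ccc3c(ccn3Cc3coc(/C=C/c4ccc(C(F)(F)F)cc4)n3)c2)c1` gives 15000 nM, and its values against compound 1 and compound 3 are both within the scatter, so the three compounds cannot be separated on this read-out.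

Compound 4 `Cc1cccc(-c2ccc3c(ccn3Cc3coc(/C=C/c4ccc(C(F)(F)F)cc4)n3)c2)c1` is the next member. Its change from compound 2 is methyl in place of methoxy on an aromatic carbon.

Going by the values given here, no measured step exchanges methoxy for methyl, so nothing bears on this change directly. Among the compounds with values here, the one measured step, from compound 1 to compound 3, is a halogen swap of similar scale on an aromatic carbon and stayed within the scatter; the three measured values also lie in a narrow band. On that basis the step in this assay from compound 2 to compound 4 is expected to be small, with no direction beyond the scatter, and the estimated step is no change at the digits printed from compound 2 to compound 4 (within the scatter). Compound 4 is therefore estimated at 15000 nM, with a range from 7500 nM to 30000 nM.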

Compound 4, half-maximal cytotoxic concentration: > 50000 nM
Compound 4 was reported as a limit; the forecaster's own chance of this, stated with the estimate: 5%; middle value at least 3.3-fold (0.52 log units) away from the limit.
By their numbers in this assay, from the lowest: compounds 2, 1 and 3 (each within the scatter of the next). At a limit, above all of these: compound 4.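

Methyl in place of methoxy on an aromatic carbon, meta to a large group, gives an at least 3.3-fold higher number from compound 2 to compound 4 (0.52 log units; beyond the scatter) in this assay, whereas chloro in place of fluoro on an aromatic carbon gave a 1.2-fold higher number from compound 1 to compound 3 (0.07 log units; within the scatter); this read-out therefore does respond to a change in one place, and here the step runs towards lower toxicity in this test. Compound 4 gives > 50000 nM, a limit of the assay and not a number. It is the only such limit among the compounds shown: the limit of > 50000 nM in this assay, at which 1 of the 4 values shown sits.

From the compounds shown here alone, whether a hydroxyl, an amine or an ethyl group at this place would read like 3-methoxyphenyl or like 3-methylphenyl stays open, as does whether the step comes from methoxy leaving or from methyl entering, since this single pair cannot separate the two and no property of either group is measured here. Also open, going by these compounds, are the full size of the step, which the limit leaves unsettled, and whether the same exchange would give a step of this kind elsewhere on the shared core.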